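This account rests on a few compounds, and the source may have more. Where it says the series, first, only, none or still open, it means among the compounds named here.

Measured in a functional assay on HCT-116 cells (Homo sapiens) for inhibition, read by sulforhodamine B assay, with a stated time of 3 days; on this read-out higher numbers stand for weaker inhibition of growth and lower numbers for stronger inhibition of growth:
- compound 1 `O=C(/C=C/c1ccccc1Cl)c1ccc(OCc2ccccc2)cc1`: 14900 nM
- compound 2 `COc1ccc(CCC(=O)c2ccccc2)cc1`: > 100000 nM (a limit)
- compound 3 `Cc1ccc(COc2ccc(C(=O)/C=C/c3ccc(F)cc3)cc2)cc1`: > 50000 nM (a limit)

In this assay, among the compounds with values here, compound 1 gives 14900 nM, the only true number in this small set. Compound 2 reads > 100000 nM, which is a limit of the assay. Compound 3 reads > 50000 nM, which is also a limit.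

Compound 4 `COc1cccc(/C=C/C(=O)c2ccc(OCc3ccccc3)cc2)c1` keeps the core of compound 1 and changes one group: 3-methoxyphenyl in place of 2-chlorophenyl on a double-bonded chain carbon bound to a double-bonded chain carbon. Within the data shown here, no measured pair tests this exchange, so its size has no direct precedent. No step beyond the usual scatter is expected, and the estimate stays anchored on compound 1 at 14900 nM. The expected step is a 1.2-fold higher number from compound 1 to compound 4 (0.08 log units; within the scatter). Among the measured compounds shown here, only one true number supports this expectation, so the range is kept wide, and a reading at a limit remains possible. Compound 4 is estimated at 18000 nM, with an expected range of 6000 nM to 55000 nM.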

Compound 4, concentration for 50% growth inhibition: 35400 nM
Estimate against measurement, compound 4: 2.0-fold (0.29 log units) below; the measured number falls inside the stated range.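

In this assay, the exchange of 2-chlorophenyl for 3-methoxyphenyl on a double-bonded chain carbon bound to a double-bonded chain carbon gives a 2.4-fold higher number from compound 1 to compound 4 (0.38 log units; beyond the scatter). Within the data shown here, this is the first step that can be read as a number, as the earlier compounds offered only one true value and two limits. It shows that growth inhibition responds to the aryl group at this place, though only modestly, and nothing measured here accounts for the step.

Among these compounds, the single exchange does not separate the loss of the chlorine from the entry of the methoxy group. Going by these compounds, how an amine or a carboxylic acid would read at this same place also stays open, so the step gives no trend across groups.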